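A few compounds are considered here, and "the series" means these few. Any claim that something is new, unique, unknown or untested is made for them only; others in the source may bear on it.

The series is followed in an assay on CHO cells for displacement of a labelled ligand from 5-hydroxytryptamine receptor 7 (Homo sapiens); a lower number here means a stronger inhibitor, a higher number a weaker inhibitor. Compound 1 `O=[N+]([O-])c1ccc(S(=O)(=O)N(CCCN2CCN(c3ccccc3)CC2)CC2CCCCC2)cc1` gives 87 nM in this assay. Within the data shown here, compound 2 `CC(CCN1CCN(c2ccccc2)CC1)NS(=O)(=O)c1ccc2ccccc2c1` gives 657 nM, the highest of the two numbers known so far; its nearest neighbour is compound 1, whose number is lower by an amount beyond the scatter. Among the measured compounds shown here, the two compounds differ in more than one place, so their values show only that compound 2 is the weaker of the pair in this assay, not which part of the structure accounts for it.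

Compound 3 `COc1ccccc1N1CCN(CCC(C)NS(=O)(=O)c2ccc3ccccc3c2)CC1` has not yet been measured. It differs from compound 2 in one place: methoxy in place of hydrogen on an aromatic carbon. For the measured compounds named here, no measured pair shows this change, so no step for it is known from the compounds at hand. The expectation is a moderate step toward a lower number, by a 2.6-fold lower number from compound 2 to compound 3 (0.42 log units; beyond the scatter), rather than a change within the scatter or a step the other way. Compound 3 is accordingly expected to give about 250 nM in this assay, within a range from 80 nM to 800 nM.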

Compound 3, half-maximal inhibitory concentration: 316 nM
Compound 3: the middle estimate sits 1.3-fold (0.10 log units) below what was measured; low and high end bracket the measured number.
By their numbers in this assay, from the lowest: compound 1; then compound 3; then compound 2.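

In this assay, among these compounds, the change from phenyl to 2-methoxyphenyl gives the only single-place step so far, which reads a 2.1-fold lower number from compound 2 to compound 3 (0.32 log units; beyond the scatter) and is modest in size. The earlier pair differed in more than one place and could say nothing about any single part of the structure, whereas this step shows that methoxy is accepted on this aromatic carbon, ortho to a large group, and that the number moves down rather than up. Nothing at hand gives a reason for this step.

Still open, as far as these compounds go, is whether the step depends on methoxy itself, which a hydroxyl, an ethoxy, a fluorine or a chlorine at this same place would test, and whether methoxy on another carbon of this ring would give a step of similar size. Also open, from the compounds shown here alone, is whether the same change would carry over to the core of compound 1, which stands at 87 nM with its phenyl unsubstituted, or holds only on the core shared by compound 2 and compound 3.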